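The compounds below may be only part of what the source reports. "The series", "measured", "known", "first", "only" and "open" are said of these compounds alone.

Measured so far in a functional assay on HT-29 cells (Homo sapiens) for cytotoxicity, read by MTT assay, with a stated time of 24 h; a higher number here means a weaker inhibitor, a lower number a stronger inhibitor:
compound 1, `O=Cc1ccccc1OCc1cn(CCCOc2ccc3ccc(=O)oc3c2)nn1`: 18900 nM
compound 2, `O=Cc1ccc(OCc2cn(CCCOc3ccc4ccc(=O)oc4c3)nn2)cc1`: 100000 nM
compound 3, `O=Cc1cc(Br)ccc1OCc1cn(CCCOc2ccc3ccc(=O)oc3c2)nn1`: 7470 nM

Compound 3 has the lowest number of the three. The steps of a 2.5-fold lower number from compound 1 to compound 3 (0.40 log units; beyond the scatter) and a 13-fold lower number from compound 2 to compound 3 (1.13 log units; beyond the scatter) both lie beyond the scatter, so it stands clearly apart from the other two in this assay.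

Compound 4, `O=Cc1cc([N+](=O)[O-])ccc1OCc1cn(CCCOc2ccc3ccc(=O)oc3c2)nn1`, has not yet been measured. It differs from compound 3 by nitro in place of bromo on an aromatic carbon. Among the measured compounds shown here, only one measured step touches that aromatic carbon: a 2.5-fold lower number from compound 1 to compound 3 (0.40 log units; beyond the scatter), where a bromo group entered in place of hydrogen and the number fell modestly. For the measured compounds named here, no measured step exchanges one substituent for another at that carbon, and no measured compound carries a nitro group, so the direction of this exchange is not fixed by the data. Going by the values given here, since the single known step at this carbon was modest, a swap of one group for another there is expected to move the number by no more than a modest amount, in either direction. Compound 4 is therefore expected to stay close to its neighbour, and the estimated step is a 1.2-fold higher number from compound 3 to compound 4 (0.08 log units; within the scatter). For compound 4 the estimated value in this assay is 9000 nM, with a range from 3000 nM to 30000 nM.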

Compound 4, half-maximal inhibitory concentration: 53600 nM
The estimate for compound 4 lay 6.0-fold (0.77 log units) below the measured number; the whole stated range lies below it.
By their numbers in this assay, from the lowest: compound 3; then compound 1; then compounds 4 and 2 (each within the scatter of the next).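

In this assay, among the compounds shown here, the aromatic carbon para to a large group proves sensitive to which group it carries: the step of a 7.2-fold higher number from compound 3 to compound 4 (0.86 log units; beyond the scatter) for nitro in place of bromo is larger than the single step known before at this carbon. Measured against hydrogen, the two groups pull in opposite directions, since nitro gives a 2.8-fold higher number from compound 1 to compound 4 (0.45 log units; beyond the scatter) while bromo had lowered the number, so a substituent here can either help or hurt. The step of a 1.9-fold lower number from compound 2 to compound 4 (0.27 log units; within the scatter) means these two compounds cannot be told apart, even though they differ in both the formyl position and the nitro group.

On these data alone, whether a chloro, methoxy or amino group at this carbon would follow bromo or nitro remains open. Nothing measured here explains why bromo and nitro differ.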